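The compounds below may be only part of what the source reports. "The series", "measured", "known", "first", "only" and "open" are said of these compounds alone.

Compound 1: `CCn1c(C(=O)N[C@H](C)C(=O)OC)ccc1C(CC)(CC)c1ccc(OCS(=O)(=O)c2ccccc2)c(C)c1`. In a functional assay on MCF7 cells (Homo sapiens) for antiproliferative activity, read by MTT assay, with a stated time of 24 h (on this read-out lower numbers stand for stronger inhibition and higher numbers for weaker inhibition), compound 1 gives > 50000 nM, which is a limit of the assay.
Compound 2: `CCn1c(C(=O)N[C@@H](C)CO)ccc1C(CC)(CC)c1ccc(OCS(=O)(=O)c2ccccc2)c(C)c1`. In this assay compound 2 gives 10800 nM.

Compound 2 therefore holds the only number shown in this assay; the other value is a limit, namely (the limit of > 50000 nM in this assay, at which 1 of the 2 values shown sits). Going by the values given here, the single measured step, an at least 4.6-fold lower number from compound 1 to compound 2 (0.66 log units; beyond the scatter), concerns the same amide-type nitrogen as the step now followed, but its two groups are different from the group that enters here.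

Compound 3 is `CCn1c(C(=O)N[C@@H](C(=O)O)C(C)C)ccc1C(CC)(CC)c1ccc(OCS(=O)(=O)c2ccccc2)c(C)c1`. Its difference from compound 2 is 1-carboxy-2-methylpropyl in place of 1-(hydroxymethyl)ethyl on an amide-type nitrogen. Among the compounds with values here, because the step of an at least 4.6-fold lower number from compound 1 to compound 2 (0.66 log units; beyond the scatter) is the only guide and does not involve 1-carboxy-2-methylpropyl, no direction is established for this change; compound 3 is expected to show no step beyond the scatter, so the estimate of a 1.9-fold higher number from compound 2 to compound 3 (0.27 log units; within the scatter) carries wide uncertainty. With that caution, compound 3 is estimated at 20000 nM in this assay, within a range from 5000 nM to 80000 nM, and a result reported only as a limit remains a real possibility.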

Compound 3, half-maximal inhibitory concentration: 44700 nM
Compound 3: the middle estimate sits 2.2-fold (0.35 log units) below what was measured; low and high end bracket the measured number.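

On the amide-type nitrogen, this assay now shows that the change of group can also raise the number: 1-carboxy-2-methylpropyl in place of 1-(hydroxymethyl)ethyl gives a 4.1-fold higher number from compound 2 to compound 3 (0.62 log units; beyond the scatter), which leaves compound 2, with its 1-(hydroxymethyl)ethyl group, as the strongest of the three compounds shown. The other new comparison, an at least 1.1-fold lower number from compound 1 to compound 3 (0.04 log units; that floor lies within the scatter), sets no order between these two compounds. Compound 1 remains at a limit of the assay: the limit of > 50000 nM in this assay, at which 1 of the 3 values shown sits.

The step to compound 3 alters both the end of the group, a hydroxymethyl giving way to a carboxylic acid, and the chain that carries it, so the compounds shown do not separate these two parts, and a group such as 1-carboxyethyl or 1-(hydroxymethyl)-2-methylpropyl would be needed to tell them apart. On these data alone, how an amine or a longer chain ending in a hydroxyl would read on this nitrogen also remains open, as does whether any group here can bring the number below that of compound 2.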